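Shortening the side chain of compound 1

The source may hold more compounds than are shown below. What is called first, only, known or untested is meant among the compounds shown, and "the series" means these compounds.

Values measured in an ADME assay on S9 fraction (Rattus norvegicus) for metabolic stability, with a stated time of 60 min (on this read-out higher numbers stand for a more stable compound and lower numbers for a less stable compound), so far

- compound 1 `CC(C)(O)c1ccc(-c2cnc3c(n2)N(CCC2CCOCC2)C(=O)CN3)cn1` gives 73%
- compound 2 `O=C1CNc2ncc(-c3ccc(-c4nc[nH]n4)cc3)nc2N1CCC1CCOCC1` gives 48%
- compound 3 `CC(C)(O)c1ccc(-c2cnc3c(n2)N(CC2CCCCC2)CC(=O)N3)cn1` gives 16%

Compound 1 stands highest of the three in this assay, and its gaps to compound 2 and to compound 3 both lie beyond the scatter. The next compound, compound 4 `CC(C)(O)c1ccc(-c2cnc3c(n2)N(CC2CCOCC2)C(=O)CN3)cn1`, has not yet been measured. It differs from compound 1 in one place (oxan-4-yl in place of (oxan-4-yl)methyl on a saturated chain carbon bound to an amide-type nitrogen in a ring). In words, oxan-4-yl takes the place of (oxan-4-yl)methyl on a saturated chain carbon bound to an amide-type nitrogen in a ring.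

Among the compounds with values here, no pair among the measured compounds differs in one place only, so the data give no direct guide to the size of this step. The expectation therefore starts from compound 1 (73%), whose core and other substituent stay unchanged in compound 4. A small upward move is expected (a number 5 percentage points higher from compound 1 to compound 4 (within the scatter)), and it is not expected to lie beyond the scatter. The estimated value for compound 4 is 78%, with an expected range from 60% to 92% as its ends.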

Compound 4, percent of the compound remaining: 83%
Compound 4: the middle estimate sits 5 percentage points below what was measured, within the range that was stated.
By their numbers in this assay, from the lowest: compound 3; then compound 2; then compounds 1 and 4 (each within the scatter of the next).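

In this assay, within the data shown here, this pair is the first to isolate a single change, and it gives a number 10 percentage points higher from compound 1 to compound 4 (within the scatter). On a saturated chain carbon bound to an amide-type nitrogen in a ring, oxan-4-yl and (oxan-4-yl)methyl therefore cannot be told apart on this read-out, with the shared core and the other substituent held fixed, so shortening the chain by this one step does not cost measurable stability here and compound 4 stays in the same band as compound 1. The data give no measured account of what lies behind this result.

Still open, going by these compounds, is whether this tolerance extends to a different group in the same place, such as a saturated ring amine, a carboxylic acid or a longer chain carrying the oxane ring. One step on a single background also leaves open whether the same shortening would read the same way with the other substituent of compound 2 in place.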